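Anilide substituent: methoxy, ester, ketone, amide

The source may hold more compounds than are shown below. What is called first, only, known or untested is meant among the compounds shown, and "the series" means these compounds.

Among the measured compounds shown here, in an assay on isolated protein for inhibition of long-chain fatty acid transport protein 1 (Homo sapiens) (on this read-out lower numbers stand for stronger inhibition and higher numbers for weaker inhibition), the three measured members share one core and differ only in the group on the anilide. Compound 1 `CCn1c(CNc2ccccc2)nnc1SCC(=O)Nc1ccc(OC)cc1` carries methoxy; its value in this assay is a limit, > 1000 nM. Compound 2 `CCn1c(CNc2ccccc2)nnc1SCC(=O)Nc1ccc(C(=O)OC)cc1` carries methoxycarbonyl and gives 540 nM in this assay. Compound 3 `CCn1c(CNc2ccccc2)nnc1SCC(=O)Nc1ccc(C(C)=O)cc1` carries acetyl; its value is again a limit, > 1000 nM. That is the limit of > 1000 nM in this assay, at which 2 of the 3 values shown sit, so compound 3 stands only as a limit, and a step that the two limits leave unreadable from compound 1 to compound 3. Against the one numbered value, the exchange at the carbonyl reads an at least 1.8-fold higher number from compound 2 to compound 3 (0.26 log units; that floor lies within the scatter), while an at least 1.8-fold lower number from compound 1 to compound 2 (0.26 log units; that floor lies within the scatter).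

Compound 4 `CCn1c(CNc2ccccc2)nnc1SCC(=O)Nc1ccc(C(=O)NC)cc1` differs from compound 3 by methylamino in place of methyl on a carbonyl carbon. The step that bears on it is the one on the same carbonyl carbon, an at least 1.8-fold higher number from compound 2 to compound 3 (0.26 log units; that floor lies within the scatter): there methyl replaced methoxy and the number rose to the limit, and methylamino now replaces that methyl. With the starting point a limit, the size of an at least 1.4-fold lower number from compound 3 to compound 4 (0.15 log units; that floor lies within the scatter) is expected only loosely, toward lower numbers. Compound 4 is estimated at 700 nM in this assay, between 300 nM and 2000 nM, with a fair chance that only a limit is reported.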

Compound 4, half-maximal inhibitory concentration: > 1000 nM
Compound 4: a limit, no number (the forecaster's own chance of this, stated with the estimate: 35%); middle value at least 1.4-fold (0.15 log units) from the limit.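

With methylamino on the carbonyl carbon, compound 4 also fails to give a number in this assay, and the series still holds only one numbered value, that of compound 2, with the others gathered at a single limit: the limit of > 1000 nM in this assay, at which 3 of the 4 values shown sit.

Replacing the methoxy of the ester with methylamino gives an at least 1.8-fold higher number from compound 2 to compound 4 (0.26 log units; that floor lies within the scatter), so this second replacement on the same carbonyl carbon again ends at the limit, but its floor does not establish a change beyond the scatter. The steps from compound 1 and from compound 3 to compound 4 cannot be read, as both ends are limits, so methylcarbamoyl cannot be ordered against methoxy or acetyl.

As far as these compounds go, it remains open how far compound 1, compound 3 and compound 4 lie past the limit, and so whether they differ from each other at all. From the compounds shown here alone, whether a carboxylic acid, an ethyl ester or a dimethylamide on the same aromatic carbon would hold, improve on or lose the value of compound 2 at 540 nM is also open.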